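Swapping the Dichlorophenyl Ring for Naphthyl on the Ether Oxygen

This account rests on a few compounds, and the source may have more. Where it says the series, first, only, none or still open, it means among the compounds named here.

Among the measured compounds shown here, compound 2 `CC(C)C[C@H](N)c1cc(C(F)(F)F)ccc1N1CCN(C(=O)COc2cccc(Cl)c2Cl)CC1` is one of two compounds measured in an assay on HEK293 cells for displacement of a labelled ligand from Melanocortin receptor 4 (Homo sapiens) (a lower number here means a stronger inhibitor, a higher number a weaker inhibitor), where compound 2 gives 2500 nM. For the measured compounds named here, that is the higher of the two numbers; compound 1 `CC(C)C[C@H](N)c1cc(C(F)(F)F)ccc1N1CCN(C(=O)C(C)Cc2ccc(Cl)cc2)CC1` gives 47 nM, and the only measured step, a 53-fold higher number from compound 1 to compound 2 (1.73 log units; beyond the scatter), replaced an entire side group on the carbonyl carbon. Compound 3 `CC(C)C[C@H](N)c1cc(C(F)(F)F)ccc1N1CCN(C(=O)COc2cccc3ccccc23)CC1` keeps the core and the ether linker of compound 2 and differs in one place: naphthalen-1-yl in place of 2,3-dichlorophenyl on an oxygen on a saturated carbon. Going by the values given here, no measured step alters just the ring on that oxygen, so the single known step is only a loose guide: it shows that this arm of the molecule can shift the number a great deal, but says nothing about exchanging one ring group for another while the linker stays. Among the compounds with values here, with no direct precedent, the expected step of a 1.3-fold lower number from compound 2 to compound 3 (0.10 log units; within the scatter) is small, not clearly beyond the scatter in either direction. Compound 3 is therefore estimated at 2000 nM, with a likely range from 500 nM to 8000 nM.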

Compound 3, inhibition constant: 2600 nM
Compound 3: the middle estimate sits 1.3-fold (0.11 log units) below what was measured, within the range that was stated.
By their numbers in this assay, from the lowest: compound 1; then compounds 2 and 3 (each within the scatter of the next).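

Exchanging 2,3-dichlorophenyl for naphthalen-1-yl on the oxygen gives a 1.0-fold higher number from compound 2 to compound 3 (0.02 log units; within the scatter) in this assay, so a ring group with two chlorine atoms and one with two aromatic rings of carbon only cannot be told apart at this position. With the ether linker kept, the change of ring group leaves the distance from the stronger compound large, at a 55-fold higher number from compound 1 to compound 3 (1.74 log units; beyond the scatter). No measurement here explains why the two ring groups read alike.

Still open, going by these compounds, is whether the large gap to compound 1 follows the ether linker, the ring group or the whole side group, since that step changes all of them at once. Also open, on these data alone, is how a plain phenyl on the oxygen, an amine on the ring or a longer chain in place of the linker would read.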